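This account rests on a few compounds, and the source may have more. Where it says the series, first, only, none or still open, it means among the compounds named here.

Measured so far in an ADME assay on isolated protein for inhibition of Amine oxidase [flavin-containing] B (Homo sapiens); on this read-out lower numbers stand for stronger inhibition and higher numbers for weaker inhibition:
compound 1 `C#CCNC1CCc2c(SCc3cccc(C)c3)cccc21` gives > 100000 nM, which is a limit of the assay and not a number.
compound 2 `C#CCNC1CCc2c(SCCc3cccc(F)c3)cccc21` gives 7810 nM.

Compound 1 sits at the limit of > 100000 nM in this assay, at which 1 of the 2 values shown sits; only a limit is known for it, so where it truly stands in this assay is open. Compound 3 `C#CCNC1CCc2c(SCc3ccc(C)cc3)cccc21` has not yet been measured. It differs from compound 1 by 4-methylphenyl in place of 3-methylphenyl on a saturated chain carbon bound to a sulfur. Within the data shown here, no measured pair differs in one place, so no step size is known in this assay, and compound 2 carries a different chain between the sulfur and the ring, so its value does not speak to the move from the 3-methylphenyl to the 4-methylphenyl. The step from compound 1 to compound 3 is expected to be a number no higher from compound 1 to compound 3 (the limit leaves the size open), none beyond the scatter, since compound 1 rests at the limit of > 100000 nM in this assay, at which 1 of the 2 values shown sits, and gives the change no measured footing to move from. Compound 3 is therefore estimated at 100000 nM, with a range from 30000 nM to 300000 nM, and is expected most likely to come back again as a limit only.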

Compound 3, half-maximal inhibitory concentration: 320 nM
The estimate for compound 3 lay 310-fold (2.49 log units) above the measured number; the measured number lies below the stated range.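

In this assay, the place of the methyl group on the phenyl ring proves decisive at this position: 4-methylphenyl in place of 3-methylphenyl, on a saturated chain carbon bound to a sulfur, keeps the same atoms and counts, yet gives an at least 310-fold lower number from compound 1 to compound 3 (2.49 log units; beyond the scatter). The size of this step is only a lower bound, since one end of it is a limit of the assay and not a number: the limit of > 100000 nM in this assay, at which 1 of the 3 values shown sits.

The position therefore does tolerate a substituted phenyl group, and the outcome depends on which isomer is present, something compound 1 alone could not show.

Going by these compounds, whether an unsubstituted phenyl or a 4-methoxyphenyl at this place would read nearer compound 1 or compound 3 stays open. On these data alone, compound 2 differs from compound 3 in more than one place, so the effect of the chain length on its own also stays open.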